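The source may report more compounds than this note shows. Statements on the series, on what has been measured and on what is new or still open speak of the compounds shown alone.

Three compounds have been measured in an assay on isolated protein for inhibition of Voltage-dependent L-type calcium channel subunit alpha-1C (Cavia porcellus); on this read-out higher numbers stand for weaker inhibition and lower numbers for stronger inhibition:

Compound 1 `CC1=C(C(=O)OC(C)C)C(c2[nH]cnc2Cl)C(C(=O)OC(C)C)=C(C)N1` gives 38 nM.
Compound 2 `CC1=C(C(=O)OCC2CCCCC2)C(c2[nH]cnc2Cl)C(C(=O)OCC2CCCCC2)=C(C)N1` gives 631 nM.
Compound 3 `COC(=O)C1=C(C)NC(C)=C(C(=O)OCc2ccccc2)C1c1[nH]cnc1Cl` gives 93.3 nM.

All three share the same core and differ only in the two ester groups attached to it. Compound 2, carrying two cyclohexylmethyl esters, stands at the highest number of the three and is thus the weakest inhibitor here; its nearest neighbour is compound 3, the gap to compound 1 is wider still, and both gaps lie beyond the scatter. Compound 4 `CCOC(=O)C1=C(C)NC(C)=C(C(=O)OCC2CCCCC2)C1c1[nH]cnc1Cl` is one step away from compound 2: methyl in place of cyclohexyl on a saturated chain carbon bound to an oxygen next to a carbonyl group. One of the two large ester groups is cut back to a small one while the other stays. Compound 1 at 38 nM and compound 3 at 93.3 nM, both with smaller esters, give the lower numbers, so a drop in the number is expected here, a step of moderate size rather than one within the scatter. Compound 4 is therefore expected to give about 160 nM, with a likely range from 50 nM to 500 nM. That estimate would mean a 3.9-fold lower number from compound 2 to compound 4 (0.60 log units; beyond the scatter).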

Compound 4, half-maximal inhibitory concentration: 513 nM
Beside the measured number, compound 4's estimate is 3.2-fold (0.51 log units) below it; the measured number lies above the stated range.
By their numbers in this assay, from the lowest: compound 1; then compound 3; then compounds 4 and 2 (each within the scatter of the next).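

In this assay, cutting one ester from cyclohexylmethoxycarbonyl to ethoxycarbonyl while the other stays in place gives a 1.2-fold lower number from compound 2 to compound 4 (0.09 log units; within the scatter) and so makes no readable difference. Within the data shown here, at this position, on a saturated chain carbon bound to an oxygen next to a carbonyl group, the whole cyclohexyl ring can thus give way to methyl with no change beyond the scatter, something the earlier compounds, which differ in more than one place, could not show. Nothing measured here explains why the number holds steady.

Open, on these data alone, is whether an amine or a carboxylic acid at the end of this ester chain, or a longer chain such as hexyl, would also leave the number unchanged. Also open, as far as these compounds go, is whether the same step would stay within the scatter with a different ester in the other place.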